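The compounds below may be only part of what the source reports. "The series", "measured", "known", "first", "only" and "open" are said of these compounds alone.

The measured compounds in an ADME assay on WI-38 cells (Homo sapiens) for cytotoxicity, read by sulforhodamine B assay, with a stated time of 24 h; on this read-out lower numbers stand for stronger inhibition and higher numbers for weaker inhibition:
compound 1 `N#CCC(=O)N/N=C1\C(=O)Nc2ccc(S(=O)(=O)N3CCOCC3)cc21` gives 302000 nM
compound 2 `N=c1oc2ccccc2cc1C(=O)N/N=C1\C(=O)Nc2ccc(S(=O)(=O)N3CCOCC3)cc21` gives 132000 nM
compound 3 `O=C1Nc2ccc(S(=O)(=O)N3CCOCC3)cc2/C1=N/c1ccc(O)cc1` gives 259000 nM

Among these, compound 3 holds the second highest of the three numbers; its nearest neighbour is compound 1, and even its furthest, compound 2, stays within the scatter. Compound 4 `CC(=O)c1cccc(/N=C2\C(=O)Nc3ccc(S(=O)(=O)N4CCOCC4)cc32)c1` differs from compound 3 in a single place: 3-acetylphenyl in place of 4-hydroxyphenyl on a double-bonded nitrogen. Among the measured compounds shown here, the only measured step at that same double-bonded nitrogen is a 1.2-fold lower number from compound 1 to compound 3 (0.07 log units; within the scatter); the other, a 2.3-fold lower number from compound 1 to compound 2 (0.36 log units; beyond the scatter), altered a different part of the shared core. For the measured compounds named here, no measured pair shows one aryl group exchanged for another at this position, so no step beyond the scatter is expected in this assay. Compound 4 is therefore estimated at 260000 nM, with a range from 120000 nM to 560000 nM. That expectation amounts to a 1.0-fold higher number from compound 3 to compound 4 (0.00 log units; within the scatter).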

Compound 4, half-maximal inhibitory concentration: 177000 nM
Compound 4: middle estimate off by 1.5-fold (0.17 log units), on the high side, and the stated range covers the measured number.
By their numbers in this assay, from the lowest: compounds 2, 4, 3 and 1 (each within the scatter of the next, the first and the last beyond it).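

In this assay, among the compounds shown here, this pair gives the only direct exchange of one aryl group for another on the double-bonded nitrogen: a 1.5-fold lower number from compound 3 to compound 4 (0.17 log units; within the scatter). Replacing 4-hydroxyphenyl, which has a hydrogen-bond donor, with 3-acetylphenyl, which has none, therefore stays within the scatter, and so does the wider change of a 1.7-fold lower number from compound 1 to compound 4 (0.23 log units; within the scatter). No measured evidence here bears on the reason for these numbers. Still open, from the compounds shown here alone, is whether a phenyl group carrying an amine or a carboxylic acid on this nitrogen would move the number beyond the scatter. Also open, going by these compounds, is whether moving the acetyl group to the 4-position of the phenyl ring would matter.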